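Extending the Ketone Side Chain on the Shared Core

The source may hold more compounds than are shown below. What is called first, only, known or untested is meant among the compounds shown, and "the series" means these compounds.

Measured compounds:
- compound 1, `CCCn1c(=O)n(CC(=O)O)c(=O)c2[nH]cnc21`, limit of > 200000 nM
- compound 2, `CCCn1c(=O)n(CCO)c(=O)c2[nH]cnc21`, 50000 nM
- compound 3, `CCCn1c(=O)n(CC(C)=O)c(=O)c2[nH]cnc21`, 11400 nM

In an assay on Cerebral cortex for binding affinity to adenosine receptor A1 (Cavia porcellus), read by radioligand binding (on this read-out lower numbers stand for stronger inhibition and higher numbers for weaker inhibition), compound 1 reaches only a limit, (the limit of > 200000 nM in this assay, at which 1 of the 3 values shown sits). Compound 2 gives a number, and the move an at least 4.0-fold lower number from compound 1 to compound 2 (0.60 log units; beyond the scatter). Compound 3 sits at the lowest of the two numbers shown; the move a 4.4-fold lower number from compound 2 to compound 3 (0.64 log units; beyond the scatter), and the move an at least 17-fold lower number from compound 1 to compound 3 (1.24 log units; beyond the scatter).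

Compound 4, `CCCn1c(=O)n(CCC(C)=O)c(=O)c2[nH]cnc21`, has not been measured. It differs from compound 3 by 2-oxopropyl in place of acetyl on a saturated chain carbon bound to an aromatic nitrogen. Every measured step swaps one kind of group for another on the chain carbon bound to the aromatic nitrogen, whereas this step keeps the ketone and only lengthens the chain by one carbon. Among the compounds with values here, none of the measured steps therefore bears directly on it, and no step beyond the scatter is expected in this assay in either direction. For compound 4 the expected number is 11000 nM, with a range from 3500 nM to 40000 nM. This estimate means the step of a 1.0-fold lower number from compound 3 to compound 4 (0.02 log units; within the scatter), which is expected to stay within the usual scatter.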

Compound 4, inhibition constant: 11200 nM
Estimate against measurement, compound 4: 1.0-fold (0.01 log units) below; measured number inside the range.
By their numbers in this assay, from the lowest: compounds 4 and 3 (each within the scatter of the next); then compound 2. At a limit, above all of these: compound 1.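

In this assay, the ketone side chain turns out to tolerate lengthening: with 2-oxopropyl in place of acetyl on a saturated chain carbon bound to an aromatic nitrogen, the reading shows a 1.0-fold lower number from compound 3 to compound 4 (0.01 log units; within the scatter), so the extra carbon leaves no measurable mark. The longer ketone also keeps the lower number seen for the shorter one, with acetyl in place of hydroxy giving a 4.5-fold lower number from compound 2 to compound 4 (0.65 log units; beyond the scatter) and 2-oxopropyl in place of carboxy giving an at least 17-fold lower number from compound 1 to compound 4 (1.25 log units; beyond the scatter), so among these compounds the ketone reads lower than the hydroxy and carboxy groups at either of its two chain lengths. The second of these steps can only be read as a minimum, since compound 1 gives a limit and not a number: the limit of > 200000 nM in this assay, at which 1 of the 4 values shown sits.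

The compounds shown do not tell whether a still longer chain carrying the ketone would also leave the number unchanged, or where along such a chain the tolerance would end. They also leave open how an amine, an ester or an amide at the end of this chain would read, and they give no explanation for why the added carbon changes so little.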